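The compounds below may be only part of what the source reports. "The series", "measured", "known", "first", "only" and "open" are said of these compounds alone.

Compound 1, with the structure `COc1cc2c(/C=C3/C(=O)Nc4ccc(Cl)cc43)c(Cl)n(Cc3cc(OC)c(OC)c(OC)c3)c2cc1C`, and compound 2, with the structure `O=C1Nc2ccc(Cl)cc2/C1=C\c1c(Cl)n(CCCc2ccccc2)c2ccccc12`, were both tested in a functional assay on cells (Cancer cell lines, Homo sapiens) for cytotoxicity, with a stated time of 48 h; on this read-out lower numbers stand for stronger inhibition of growth and higher numbers for weaker inhibition of growth. In this assay compound 1 gives 2190 nM, and in this assay compound 2 gives 1950 nM. Compound 2 therefore holds the lower of the two numbers, but compound 1 lies within the usual scatter of it, so the two cannot be told apart on these data.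

Compound 3, with the structure `O=C1Nc2ccccc2/C1=C\c1c(Cl)n(CCCc2ccccc2)c2ccccc12`, has not yet been measured. It differs from compound 2 in one place: hydrogen in place of chloro on an aromatic carbon. Within the data shown here, no step between two measured compounds of this kind is available here, so there is nothing within the set to calibrate the change against. The step from compound 2 to compound 3 in this assay is expected to be small, leaning toward weaker inhibition of growth, at a 1.6-fold higher number from compound 2 to compound 3 (0.22 log units; within the scatter). Compound 3 is accordingly estimated to give 3200 nM, with a range from 1100 nM to 9500 nM.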

Compound 3, concentration for 50% growth inhibition: 12000 nM
The estimate for compound 3 lay 3.8-fold (0.57 log units) below the measured number; the whole stated range lies below it.
By their numbers in this assay, from the lowest: compounds 2 and 1 (each within the scatter of the next); then compound 3.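

In this assay, putting hydrogen in place of chloro on this aromatic carbon gives a 6.2-fold higher number from compound 2 to compound 3 (0.79 log units; beyond the scatter), a step beyond the scatter. Among these compounds, this is the first direct sign that the position matters for the read-out: the chloro group on this ring goes with stronger inhibition of growth, at least on the core of compound 2. Compound 1 and compound 2 differ in more than one place, so their pairing could not isolate any single change.

As far as these compounds go, it remains open whether fluoro, bromo, methoxy or an amine on this same carbon would match chloro or hydrogen, and whether removing chloro here would give a similar step on the core of compound 1. No measurement at hand explains the size of this step.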